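This account rests on a few compounds, and the source may have more. Where it says the series, first, only, none or still open, it means among the compounds named here.

Three compounds with the shared core and a varied alkyl group on the terminal benzene ring have been measured so far. Compound 1 `CCCc1ccc(/C=C/C(=O)Nc2ccc3nc(CCC)cc(N)c3c2)cc1` gives 3600 nM in a functional assay on HEK293 cells for activation of melanin-concentrating hormone receptor 1 (Homo sapiens), read by inositol phosphate accumulation; a lower number here means that less compound is needed, a higher number that more compound is needed for the effect. Compound 2 `CCCc1cc(N)c2cc(NC(=O)/C=C/c3ccc(CC)cc3)ccc2n1` gives 160 nM. Compound 3 `CCCc1cc(N)c2cc(NC(=O)/C=C/c3ccc(C(C)C)cc3)ccc2n1` gives 520 nM. On these numbers compound 3 stands second highest of the three, nearer to compound 2 than to compound 1: a 3.3-fold higher number from compound 2 to compound 3 (0.51 log units; beyond the scatter), whereas a 6.9-fold lower number from compound 1 to compound 3 (0.84 log units; beyond the scatter). The remaining step, a 23-fold lower number from compound 1 to compound 2 (1.35 log units; beyond the scatter), is the largest in the set. Compound 4 `CCCCc1ccc(/C=C/C(=O)Nc2ccc3nc(CCC)cc(N)c3c2)cc1` is the next member; the change is butyl in place of isopropyl on an aromatic carbon. All three measured steps bear on it, as each alters the same alkyl group. Going from ethyl to propyl, the reverse of a 23-fold lower number from compound 1 to compound 2 (1.35 log units; beyond the scatter), raised the number sharply, and the branched isopropyl of compound 3 sits between those two. Extending the chain further than propyl has no precedent among the measured compounds, so the estimate leans on the rise seen with chain length. For compound 4 a higher number is expected, about a 4.8-fold higher number from compound 3 to compound 4 (0.68 log units; beyond the scatter), estimated at 2500 nM with a range of 700 nM to 9000 nM.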

Compound 4, half-maximal effective concentration: 740 nM
For compound 4 the middle estimate is 3.4-fold (0.53 log units) above the measured one, within the range that was stated.
By their numbers in this assay, from the lowest: compound 2; then compounds 3 and 4 (each within the scatter of the next); then compound 1.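

Butyl, on an aromatic carbon para to a large group, does not continue the rise from ethyl to propyl: the chain is longer than in compound 1, yet the number drops (a 4.9-fold lower number from compound 1 to compound 4 (0.69 log units; beyond the scatter)). Butyl and isopropyl cannot be told apart here (a 1.4-fold higher number from compound 3 to compound 4 (0.15 log units; within the scatter)), while ethyl keeps the lowest number of the set (a 4.6-fold higher number from compound 2 to compound 4 (0.67 log units; beyond the scatter)), so the number does not follow chain length across these four compounds. One added methyl also has no fixed effect at this position, and its direction differs with the chain that receives it: the same change on two cores in this assay, a 3.3-fold higher number (0.51 log units; beyond the scatter) from compound 2 to compound 3 and a 4.9-fold lower number (0.69 log units; beyond the scatter) from compound 1 to compound 4, 16-fold (1.20 log units) apart, beyond the scatter of two such steps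

Going by these compounds, whether a longer chain such as pentyl would lower the number further, or raise it, remains open. Also open, on these data alone, is whether a cyclopropyl or methoxy group in this place would come close to ethyl.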